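This account rests on a few compounds, and the source may have more. Where it says the series, first, only, none or still open, it means among the compounds named here.

Among the compounds with values here, only two compounds have numbers so far in a functional assay on M21 cells (Homo sapiens) for inhibition, read by sulforhodamine B assay, with a stated time of 48 h (a lower number here means a stronger inhibitor, a higher number a weaker inhibitor), so any forecast here rests on thin ground. Compound 1 `CCNC(=O)Nc1ccc(/C=C\c2cc(OC)c(OC)c(OC)c2)cc1` gives 21000 nM, and compound 2 `CCNC(=O)Nc1ccc(/C=C/c2cc(OC)c(OC)c(OC)c2)cc1` gives 29000 nM. The only structural distinction between them is the fact that compounds 1 and 2 differ only in the configuration as drawn, with the double bond drawn Z in one and E in the other. The measured step is a 1.4-fold higher number from compound 1 to compound 2 (0.14 log units; within the scatter). On these numbers, compound 2 therefore cannot be separated from compound 1.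

Compound 3 `COc1cc(/C=C/c2ccc(N3CCNC3=O)cc2)cc(OC)c1OC` keeps the E double bond and the rest of the core of compound 2, but changes one group: 2-oxoimidazolidin-1-yl in place of (ethylcarbamoyl)amino on an aromatic carbon. In words, 2-oxoimidazolidin-1-yl takes the place of (ethylcarbamoyl)amino on an aromatic carbon, para to a large group. Within the data shown here, the one measured step concerns the double bond and leaves this group untouched, so it offers no direct guide to the new change. With no basis for a direction, the expectation stays anchored on compound 2 at 29000 nM, and no step beyond the scatter is expected in this assay. The estimated step is a 1.2-fold lower number from compound 2 to compound 3 (0.06 log units; within the scatter). For compound 3 the estimated value is 25000 nM, with an expected range of 8000 nM to 70000 nM.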

Compound 3, half-maximal inhibitory concentration: 550 nM
Beside the measured number, compound 3's estimate is 45-fold (1.66 log units) above it; the whole stated range lies above it.
By their numbers in this assay, from the lowest: compound 3; then compounds 1 and 2 (each within the scatter of the next).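

In this assay, the group on the aromatic carbon, para to a large group, counts for far more than the drawn configuration of the double bond: replacing (ethylcarbamoyl)amino with 2-oxoimidazolidin-1-yl gives a 53-fold lower number from compound 2 to compound 3 (1.72 log units; beyond the scatter), whereas the double-bond change alone gave a 1.4-fold higher number from compound 1 to compound 2 (0.14 log units; within the scatter). The two groups have the same number and kinds of heavy atoms, so a large change here does not require adding or removing any atoms: the entering group has one five-membered non-aromatic ring and 1 hydrogen-bond donor, while the leaving group has no ring and 2 hydrogen-bond donors. The information available on these compounds does not bear on why this swap has such a large effect.

The compounds shown cannot separate the effect of closing the ring from that of having one donor fewer, and a 3-methyl-2-oxoimidazolidin-1-yl or 2-oxopyrrolidin-1-yl group at the same place would test this more directly. From the compounds shown here alone, it also remains open whether 2-oxoimidazolidin-1-yl would give a similar number with the double bond drawn Z, as the near-equal values of compound 1 and compound 2 describe only the open-chain group.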